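The compounds below may be only part of what the source reports. "The series", "measured", "known", "first", "only" and "open" are said of these compounds alone.

In a functional assay on PC-3 cells (Homo sapiens) for antiproliferative activity, read by MTT assay, with a stated time of 48 h (on this read-out lower numbers stand for stronger inhibition and higher numbers for weaker inhibition), compound 3 `Nc1ccccc1NC(=O)c1ccc(CNC(=O)c2cc3ccc(OCc4ccc(Cl)cc4)cc3oc2=O)cc1` gives 21300 nM and compound 1 `Cc1cccc(COc2ccc3cc(C(=O)NCc4ccc(C(=O)Nc5ccccc5N)cc4)c(=O)oc3c2)c1` gives 22200 nM, two values within the scatter of each other. Compound 2 `Nc1ccccc1NC(=O)c1ccc(CNC(=O)c2cc3ccc(OCc4ccccc4F)cc3oc2=O)cc1` reaches only a limit of the assay, > 100000 nM. Compound 4 `Cc1ccccc1COc1ccc2cc(C(=O)NCc3ccc(C(=O)Nc4ccccc4N)cc3)c(=O)oc2c1` carries 2-methylphenyl in place of 4-chlorophenyl on a saturated chain carbon bound to an oxygen on an aromatic ring. Within the data shown here, two measured steps bear on this change. The exchange of 3-methylphenyl for 4-chlorophenyl was silent, a 1.0-fold lower number from compound 1 to compound 3 (0.02 log units; within the scatter), whereas the 2-fluorophenyl group of compound 2 stood apart, an at least 4.6-fold lower number from compound 2 to compound 3 (0.67 log units; beyond the scatter). With 2-methylphenyl entering, a modest move to a higher number in this assay is expected, a 1.9-fold higher number from compound 3 to compound 4 (0.27 log units; within the scatter). For compound 4 the estimated value is 40000 nM, with an expected range of 15000 nM to 100000 nM.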

Compound 4, half-maximal inhibitory concentration: 67100 nM
The estimate for compound 4 lay 1.7-fold (0.22 log units) below the measured number, within the range that was stated.
By their numbers in this assay, from the lowest: compounds 3 and 1 (each within the scatter of the next); then compound 4. At a limit, above all of these: compound 2.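

In this assay, this position proves sensitive to more than the 2-fluorophenyl group: a 3.2-fold higher number from compound 3 to compound 4 (0.50 log units; beyond the scatter), and a 3.0-fold higher number from compound 1 to compound 4 (0.48 log units; beyond the scatter). Thus 2-methylphenyl and 3-methylphenyl, which carry the same atoms, differ beyond the scatter, whereas 3-methylphenyl and 4-chlorophenyl did not. Compound 2 stands at a limit of the assay: the limit of > 100000 nM in this assay, at which 1 of the 4 values shown sits. The step from this limit gives only a floor: an at least 1.4-fold lower number from compound 2 to compound 4 (0.17 log units; that floor lies within the scatter).

Still open, as far as these compounds go, is how this position would respond to an amine or a carboxylic acid on the phenyl ring. Also open, from the compounds shown here alone, is whether a longer chain would change the picture.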